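The compounds below may be only part of what the source reports. "The series", "measured", "known", "first", "only" and "open" are said of these compounds alone.

Measured in a functional assay on SK-OV-3 cells (Homo sapiens) for antiproliferative activity, read by MTT assay, with a stated time of 72 h; a higher number here means a weaker inhibitor, a lower number a stronger inhibitor:
- compound 1 `O=C(CCc1cccc2c1B(O)OC2)Nc1cccc(-c2ccccc2)c1`: 250 nM
- compound 2 `COc1ccc(-c2cccc(NC(=O)CCc3cccc4c3B(O)OC4)c2)cc1`: 48 nM

Compound 2 holds the lower of the two numbers. Among the measured compounds shown here, the only measured step is a 5.2-fold lower number from compound 1 to compound 2 (0.72 log units; beyond the scatter), for methoxy in place of hydrogen on an aromatic carbon. Compound 3 `CSc1cccc(-c2cccc(NC(=O)CCc3cccc4c3B(O)OC4)c2)c1` departs from compound 2 as follows: 3-(methylsulfanyl)phenyl in place of 4-methoxyphenyl on an aromatic carbon. For the measured compounds named here, no measured compound carries this group, so that one step is only a partial guide. Compound 3 gives up the methoxy seen in compound 2 at 48 nM, so part of that gain may be lost. The expected change is a 1.9-fold higher number from compound 2 to compound 3 (0.27 log units; within the scatter), a modest step of no greater size than the measured one. For compound 3 the estimated value is 90 nM, with an expected range of 30 nM to 270 nM.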

Compound 3, half-maximal inhibitory concentration: 150 nM
For compound 3 the middle estimate is 1.7-fold (0.22 log units) below the measured one; the measured number falls inside the stated range.
By their numbers in this assay, from the lowest: compound 2; then compounds 3 and 1 (each within the scatter of the next).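

In this assay, the step to 3-(methylsulfanyl)phenyl shows that the gain seen with 4-methoxyphenyl does not extend to every substituted ring at this place, giving a 3.1-fold higher number from compound 2 to compound 3 (0.49 log units; beyond the scatter) on this change. Methylsulfanyl in place of hydrogen gives a 1.7-fold lower number from compound 1 to compound 3 (0.22 log units; within the scatter) and so leaves compound 3 not distinguishable from compound 1, which has hydrogen there. Nothing shown gives a reason for either step. How a 4-(methylsulfanyl)phenyl or a 3-methoxyphenyl group would behave stays open, so the compounds shown do not separate the change of oxygen to sulfur from the change of place on the ring.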